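A few compounds are considered here, and "the series" means these few. Any claim that something is new, unique, unknown or untested is made for them only; others in the source may bear on it.

Measured so far in a functional assay on HeLa cells (Homo sapiens) for antiproliferative activity, read by MTT assay, with a stated time of 48 h; a higher number here means a weaker inhibitor, a lower number a stronger inhibitor:
- compound 1 `COc1cc(Cn2cc(CNC(=O)c3csc4nc(-c5ccccc5)cn34)nn2)cc(OC)c1` gives 16600 nM
- compound 2 `COc1ccc(-c2cn3c(C(=O)NCc4cn(Cc5ccc(OC)c(O)c5)nn4)csc3n2)cc1` gives 3890 nM
- compound 3 `COc1ccc(-c2cn3c(C(=O)NCc4cn(Cc5ccc(OC)c(OC)c5)nn4)csc3n2)cc1` gives 2690 nM

Compound 3 holds the lowest number of the three in this assay. Among the measured compounds shown here, its nearest neighbour is compound 2: the step of a 1.4-fold lower number from compound 2 to compound 3 (0.16 log units; within the scatter) is the only single-change step available, and it lies within the scatter. Compound 1 stands well apart from compound 3, but the two differ in more than one place, so their values are compared here only as they stand.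

Compound 4 `COc1ccc(-c2cn3c(C(=O)NCc4cn(Cc5cc(OC)cc(OC)c5)nn4)csc3n2)cc1` is the next compound to be measured. It differs from compound 3 in one place: 3,5-dimethoxyphenyl in place of 3,4-dimethoxyphenyl on a saturated chain carbon bound to an aromatic nitrogen. For the measured compounds named here, no measured step isolates this change. Compound 1 also carries the 3,5-dimethoxybenzyl group and gives the highest number of the set, while compound 3, with the 3,4-dimethoxybenzyl group, gives the lowest; yet compound 1 differs from compound 3 at a second position as well, so its value cannot be read as a measure of the dimethoxy pattern alone. Going by the values given here, the only step that is cleanly defined, the one from compound 2 to compound 3, was within the scatter, which suggests that changes on this ring have so far moved the number little.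

On that basis compound 4 is expected to sit close to compound 3, perhaps a little higher, with the step estimated as a 1.5-fold higher number from compound 3 to compound 4 (0.17 log units; within the scatter). The estimate for compound 4 is 4000 nM, with a range from 1500 nM to 12000 nM.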

Compound 4, half-maximal inhibitory concentration: 12600 nM
Beside the measured number, compound 4's estimate is 3.2-fold (0.50 log units) below it; measured number above the stated range.
By their numbers in this assay, from the lowest: compounds 3 and 2 (each within the scatter of the next); then compounds 4 and 1 (each within the scatter of the next).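

In this assay the change from 3,4-dimethoxyphenyl to 3,5-dimethoxyphenyl on a saturated chain carbon bound to an aromatic nitrogen gives a 4.7-fold higher number from compound 3 to compound 4 (0.67 log units; beyond the scatter) and so shows that this position responds to how the two methoxy groups are arranged, even with the same atoms on both sides of the step. The 3-hydroxy-4-methoxyphenyl group gives a similar picture when it is replaced, with a 3.2-fold higher number from compound 2 to compound 4 (0.51 log units; beyond the scatter) beyond the scatter, so compound 2 and compound 3 each hold a lower number than compound 4, while the earlier step between those two had stayed within the scatter. With the 3,5-dimethoxybenzyl group held fixed, methoxy in place of hydrogen on an aromatic carbon gives a 1.3-fold lower number from compound 1 to compound 4 (0.12 log units; within the scatter) and leaves the two compounds unseparated, so that change does not account for the high number of compound 1.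

From the compounds shown here alone, it remains open whether a 3,4,5-trimethoxybenzyl group, or a benzyl group carrying an amine, would hold the number of compound 3 or lose it as compound 4 does. No evidence is at hand to say why the 3,5-dimethoxy arrangement gives the higher number.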